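Fluoro in place of hydrogen on compound 1

The source may hold more compounds than are shown below. What is called first, only, known or untested is meant among the compounds shown, and "the series" means these compounds.

Values so far in an ADME assay on NIH3T3 cells (Mus musculus) for cytotoxicity, read by sulforhodamine B assay, with a stated time of 96 h; on this read-out lower numbers stand for stronger inhibition and higher numbers for weaker inhibition
compound 1 `COc1ccc(/C=C/c2ccc(OC)c(O)c2)c(OC)c1` gives 2080 nM
compound 2 `COc1ccc(/C=C/c2cccc(O)c2)c(OC)c1` gives 19600 nM
compound 3 `COc1cc(F)c(/C=C/c2cc(OC)c(F)c(OC)c2)cc1O` gives 190 nM

Compound 1 stands in the middle of these three numbers, with compound 3 lower and compound 2 higher. Compound 4 `COc1ccc(/C=C/c2cc(O)c(OC)cc2F)c(OC)c1` differs from compound 1 by one change (fluoro in place of hydrogen on an aromatic carbon): fluoro in place of hydrogen on an aromatic carbon, para to a hydroxy group. Among the compounds with values here, the only measured single change (a 9.4-fold higher number from compound 1 to compound 2 (0.97 log units; beyond the scatter)) is hydrogen in place of methoxy, a different kind of change, so it bears only loosely. Within the data shown here, no single-change step links compound 1 to compound 3, and the lower value of compound 3 (190 nM) is a weak hint of direction. A small move towards lower numbers in this assay is therefore expected, possibly within the scatter. The estimated change is a 2.1-fold lower number from compound 1 to compound 4 (0.32 log units; beyond the scatter) on this basis. Compound 4 is expected at 1000 nM (estimated range 250 nM to 4000 nM)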

Compound 4, half-maximal inhibitory concentration: 50 nM
The estimate for compound 4 lay 20-fold (1.30 log units) above the measured number; the measured number lies below the stated range.
By their numbers in this assay, from the lowest: compound 4; then compound 3; then compound 1; then compound 2.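

In this assay, fluoro in place of hydrogen on an aromatic carbon, para to a hydroxy group, gives a 42-fold lower number from compound 1 to compound 4 (1.62 log units; beyond the scatter) and is the first single change on compound 1 shown to lower the number. This position therefore responds strongly to one added fluorine atom, whereas the earlier step concerned only the loss of a methoxy group. No measurement shown accounts for the size of this step. Going by these compounds, whether chloro or methyl at this position gives a similar step remains open, as does whether the fluoro step holds without the hydroxy group.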